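The compounds below may be only part of what the source reports. "The series", "measured", "known", "first", "only" and "open" are said of these compounds alone.

Of the compounds shown here, three built on a shared core have been tested in an ADME assay on MT2 cells (Homo sapiens) for cytotoxicity, read by XTT assay, with a stated time of 4 days; a lower number here means that less compound is tolerated, a higher number that more compound is tolerated. Compound 1 `CCOC(=O)C(=Cc1cc(C)n(-c2cccc(-c3nnn[nH]3)c2)c1C)C(=O)OCC` gives 77400 nM. Compound 2 `COc1cccc(N2C(=O)/C(=C/c3cc(C)n(-c4cccc(-c5nnn[nH]5)c4)c3C)SC2=S)c1` gives 40600 nM, and compound 3 `Cc1cc(/C=C2\SC(=S)N(c3cccc(Br)c3)C2=O)c(C)n1-c1cccc(-c2nnn[nH]2)c1` gives 22600 nM. Among these three numbers compound 3 stands lowest; the gap to compound 2 is within the scatter of repeated measurements, while the gap to compound 1 lies beyond it. Among the measured compounds shown here, only one pair of measured compounds differs in a single place, and that pair gives a 1.8-fold lower number from compound 2 to compound 3 (0.25 log units; within the scatter), so exchanging one group on the aromatic ring attached to the ring nitrogen has left the read-out essentially unchanged.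

Compound 4 `Cc1cc(/C=C2\SC(=S)N(c3ccc(O)cc3)C2=O)c(C)n1-c1cccc(-c2nnn[nH]2)c1` has not yet been measured. It differs from compound 3 in one place: 4-hydroxyphenyl in place of 3-bromophenyl on an amide-type nitrogen in a ring. For the measured compounds named here, the only measured step that bears on this change is the one from compound 2 to compound 3, which also exchanged a group on that same aromatic ring and stayed within the scatter. On that basis no movement beyond the scatter is expected here either. Compound 4 is therefore expected to give 30000 nM, with a range from 12000 nM to 75000 nM. The step of a 1.3-fold higher number from compound 3 to compound 4 (0.12 log units; within the scatter) that this estimate implies is expected to stay within the scatter.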

Compound 4, half-maximal cytotoxic concentration: 45600 nM
Estimate against measurement, compound 4: 1.5-fold (0.18 log units) below, and the stated range covers the measured number.
By their numbers in this assay, from the lowest: compounds 3, 2, 4 and 1 (each within the scatter of the next, the first and the last beyond it).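

In this assay, replacing 3-bromophenyl with 4-hydroxyphenyl adds a hydrogen-bond donor and a hydrogen-bond acceptor on the amide-type nitrogen and gives a 2.0-fold higher number from compound 3 to compound 4 (0.30 log units; within the scatter), while replacing 3-methoxyphenyl with the same group gives a 1.1-fold higher number from compound 2 to compound 4 (0.05 log units; within the scatter). Among the compounds shown here, the earlier step compared only two groups with their substituent written at the 3-position, whereas these steps add a group with its substituent at the 4-position, and all three groups on this nitrogen now lie within the scatter of one another. No independent measurement is available to explain this tolerance of the change at this position.

The step from 3-bromophenyl to 4-hydroxyphenyl changes both the substituent and its place on the ring, so the compounds shown cannot separate those two changes; 3-hydroxyphenyl or 4-bromophenyl would be needed to do that. All three groups here are also substituted phenyl rings, which leaves open how this read-out would respond to a phenyl ring carrying an amine or a carboxylic acid, or to a simple alkyl chain on the same nitrogen.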